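Swapping the aryl group on the enone chain

The compounds below may be only part of what the source reports. "The series", "measured", "known", "first", "only" and "open" are said of these compounds alone.

Measured compounds:
- compound 1, `CNC(=O)c1cc(Oc2ccc(C(=O)/C=C/c3ccc(Cl)cc3Cl)cc2)ccn1`, a functional assay on HepG2 cells (Homo sapiens) for cytotoxicity, read by MTT assay, with a stated time of 72 h; a higher number here means a weaker inhibitor, a lower number a stronger inhibitor: 11700 nM
- compound 2, `CNC(=O)c1cc(Oc2ccc(C(=O)/C=C/c3ccc(F)cc3)cc2)ccn1`, this assay: 12600 nM
- compound 3, `CNC(=O)c1cc(Oc2ccc(C(=O)/C=C/c3ccco3)cc2)ccn1`, this assay: "not determined" (no result reported)

Compound 3 stands apart from the other two in that this assay gave no number for it; nothing can be placed against compounds 1 and 2 for it. The step under consideration goes from compound 3 to compound 4, `CNC(=O)c1cc(Oc2ccc(C(=O)/C=C/c3cccc(Cl)c3Cl)cc2)ccn1`, and the change is 2,3-dichlorophenyl in place of furan-2-yl on a double-bonded chain carbon bound to a double-bonded chain carbon.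

For the measured compounds named here, no measured step involves furan-2-yl. Going by the values given here, the only measured step, a 1.1-fold higher number from compound 1 to compound 2 (0.03 log units; within the scatter), also exchanges the aryl group on a double-bonded chain carbon bound to a double-bonded chain carbon, and it lay within the scatter, so the two dichlorophenyl and fluorophenyl analogs sit at the same level in this assay. Compound 4 carries 2,3-dichlorophenyl in the same position, so the expectation rests on compounds 1 and 2 rather than on compound 3. For compound 4 a value near those two is estimated, 12000 nM, with a range from 5000 nM to 30000 nM.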

Compound 4, half-maximal inhibitory concentration: > 50000 nM
Compound 4 was reported as a limit; the forecaster's own chance of this, stated with the estimate: 10%; middle value at least 4.1-fold (0.61 log units) away from the limit.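

The reading for compound 4 in this assay is a limit and not a number: the limit of > 50000 nM in this assay, at which 1 of the 4 values shown sits. Unlike a 1.1-fold higher number from compound 1 to compound 2 (0.03 log units; within the scatter), the new steps lie beyond the scatter: an at least 3.9-fold higher number from compound 2 to compound 4 (0.59 log units; beyond the scatter), and an at least 4.2-fold higher number from compound 1 to compound 4 (0.63 log units; beyond the scatter), with the higher number at compound 4 in both. The aryl group on a double-bonded chain carbon bound to a double-bonded chain carbon therefore does affect the read-out, and dichlorophenyl as such does not settle the level, since 2,4-dichlorophenyl and 2,3-dichlorophenyl carry the same atoms yet part beyond the scatter.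

From the compounds shown here alone, the step from compound 3 to compound 4 cannot be read, since compound 3 has no number in this assay, and how far compound 4 lies beyond its limit is unknown. Going by these compounds, whether a pyridyl group, or a phenyl ring bearing a carboxylic acid, would stand with compound 1 and compound 2 or with compound 4 remains open.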